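Positional trifluoromethyl swap on the benzylamine arm

A few compounds are considered here, and "the series" means these few. Any claim that something is new, unique, unknown or untested is made for them only; others in the source may bear on it.

Two members of the series have numbers in an ADME assay on RAW264.7 cells (Mus musculus) for cytotoxicity, read by MTT assay, with a stated time of 72 h, tested at 50 uM (a higher number here means more inhibition at the concentration tested (going by the name of the read-out), a lower number less inhibition), so far. Compound 1 `CCOC(=O)c1sc(-c2ccccn2)nc1N1CCC(NCc2ccc(F)cc2)CC1` gives 12.6% in this assay, and compound 2 `CCOC(=O)c1sc(-c2ccccn2)nc1N1CCC(NCc2ccc(C(F)(F)F)cc2)CC1` gives 14.6% in this assay. Within this pair compound 2 stands at the higher number, though the single step, a number 2 percentage points higher from compound 1 to compound 2 (within the scatter), carries no weight of its own.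

Compound 3 `CCOC(=O)c1sc(-c2ccccn2)nc1N1CCC(NCc2cccc(C(F)(F)F)c2)CC1` has not been measured in this assay. It differs from compound 2 as follows: 3-(trifluoromethyl)phenyl in place of 4-(trifluoromethyl)phenyl on a saturated chain carbon bound to an amine nitrogen. Going by the values given here, no measured step bears directly on this change; the only step available, a number 2 percentage points higher from compound 1 to compound 2 (within the scatter), concerns the group at the same attachment and was within the scatter. The expectation is therefore a step of about a number 0.4 percentage points higher from compound 2 to compound 3 (within the scatter), that is, nothing beyond the scatter. Compound 3 is estimated at 15% in this assay, with a range from 4% to 28%.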

Compound 3, a percentage reported as inhibition, at one concentration (the size of the read-out at that concentration, not a potency): 19.2%
Estimate against measurement, compound 3: 4.2 percentage points below, and the stated range covers the measured number.
By their numbers in this assay, from the lowest: compounds 1, 2 and 3 (each within the scatter of the next).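

In this assay, going by these compounds alone, the placement of the trifluoromethyl group can now be read for the first time, and it gives a number 4.6 percentage points higher from compound 2 to compound 3 (within the scatter) on this saturated chain carbon bound to an amine nitrogen, so 3-(trifluoromethyl)phenyl and 4-(trifluoromethyl)phenyl cannot be told apart here. Against the fluoro compound, the result is a number 6.6 percentage points higher from compound 1 to compound 3 (within the scatter) and thus no separation either, leaving all three aryl groups at this attachment within the scatter of one another. No measurement at hand offers an explanation for any of these numbers.

On these data alone, it remains open whether any group at this attachment can produce a step beyond the scatter, for example a nitrile, an amine or a carboxylic acid in place of the trifluoromethyl. With a single assay shown, it is also open whether the two trifluoromethyl isomers differ in any other read-out.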